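Cytotoxicity notes on a nitro-aryl methylsulfone amide series

A few compounds are considered here, and "the series" means these few. Any claim that something is new, unique, unknown or untested is made for them only; others in the source may bear on it.

Measured compounds:
compound 1 `CS(=O)(=O)c1ccc(C(=O)NCC(=O)N(Cc2ccccc2)Cc2ccccc2)cc1[N+](=O)[O-]`, in an ADME assay on HepG2 cells (Homo sapiens) for cytotoxicity, read by CellTiter-Glo and ATP content, with a stated time of 72 h (on this read-out lower numbers stand for an effect already at smaller amounts and higher numbers for an effect only at larger amounts of compound), compound 1 gives 11900 nM.
compound 2 `Cc1ccc(N2CCN(C(=O)C3CCN(C(=O)c4ccc(S(C)(=O)=O)c([N+](=O)[O-])c4)CC3)CC2)cc1`, for compound 2 only a limit is recorded, > 27000 nM.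
compound 3 `CCCN(C(=O)CN(C)C(=O)c1ccc(S(C)(=O)=O)c([N+](=O)[O-])c1)c1ccccc1`, for compound 3 likewise only a limit is recorded, > 27000 nM.

Compound 3 therefore stands not at a number but at the assay's limit; it shares that position with compound 2, as stated in the limit of > 27000 nM in this assay, at which 2 of the 3 values shown sit. Among the compounds with values here, compound 1 is the only member with a read number on this read-out.

The next compound, compound 4 `CN(Cc1cccc(F)c1)C(=O)CN(C)C(=O)c1ccc(S(C)(=O)=O)c([N+](=O)[O-])c1`, differs from compound 3 in one place: (3-fluorobenzyl)(methyl)amino in place of phenyl(propyl)amino on a carbonyl carbon. The shared core of the three measured compounds is kept unchanged, so compound 4 stays within the same series.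

Within the data shown here, no step between measured compounds is available. The closest comparison is compound 1, which carries two benzyl groups on its amide nitrogen and gives a read number, while compound 3 with its phenyl(propyl)amino group sits at the limit. The step expected from compound 3 to compound 4 in this assay is therefore towards a smaller number, but small, probably not beyond the scatter; the expected step is an at least 1.1-fold lower number from compound 3 to compound 4 (0.05 log units; that floor lies within the scatter). For compound 4 the estimated value in this assay is 24000 nM, with a range from 9000 nM to 60000 nM, and a real chance that only a limit is again reported.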

Compound 4, half-maximal effective concentration: > 27000 nM
Compound 4 was reported as a limit; the forecaster's own chance of this, stated with the estimate: 60%; middle value at least 1.1-fold (0.05 log units) from the limit.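

Within the data shown here, compound 3 and compound 4 are both recorded only as limits, so no step between them can be read: the limit of > 27000 nM in this assay, at which 3 of the 4 values shown sit. As far as these compounds go, whether (3-fluorobenzyl)(methyl)amino in place of phenyl(propyl)amino on a carbonyl carbon changes the read-out at all remains open.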